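A few compounds are considered here, and "the series" means these few. Any claim that something is new, unique, unknown or untested is made for them only; others in the source may bear on it.

Compound 1 `C[C@H](c1ccc(C(=O)NCCC(=O)O)cc1)N1C(=O)C(c2cccc(C3CC3)c2)=N[C@]12CC[C@@H](C(C)(C)C)CC2` and compound 2 `CC(C)(C)CC[C@H](c1ccc(C(=O)NCc2nn[nH]n2)cc1)N1C(=O)C(c2ccc(F)cc2)=N[C@]12CC[C@@H](C(C)(C)C)CC2` were both tested in an assay on CHO cells for displacement of a labelled ligand from Glucagon receptor (Homo sapiens), read by scintillation counting, with a stated time of 60 min; on this read-out lower numbers stand for stronger inhibition and higher numbers for weaker inhibition. In this assay compound 1 gives 56 nM, the higher of the two numbers recorded, while compound 2 gives 13 nM; the two compounds differ in several places at once, so their values can only be compared as a whole and not traced to one change.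

Compound 3 `C[C@H](c1ccc(C(=O)NCCC(=O)O)cc1)N1C(=O)C(c2ccccc2F)=N[C@]12CC[C@@H](C(C)(C)C)CC2` has not yet been measured. It differs from compound 1 in one place: 2-fluorophenyl in place of 3-cyclopropylphenyl on a carbon with a double bond to nitrogen. Within the data shown here, no step between measured compounds covers this change, so nothing in the data shows its direction. On this assay a larger aryl group accompanies the stronger of the two recorded values, and compound 3 carries a smaller group, so compound 3 is expected to show a weaker number than compound 1, with a step from compound 1 to compound 3 estimated at a 2.7-fold higher number from compound 1 to compound 3 (0.43 log units; beyond the scatter). Compound 3 is therefore expected to give about 150 nM, within a range from 50 nM to 500 nM.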

Compound 3, half-maximal inhibitory concentration: 1100 nM
Compound 3: middle estimate off by 7.3-fold (0.87 log units), on the low side; measured number above the stated range.
By their numbers in this assay, from the lowest: compound 2; then compound 1; then compound 3.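

In this assay, among these compounds, putting 2-fluorophenyl in place of 3-cyclopropylphenyl on the carbon with a double bond to nitrogen gives a 20-fold higher number from compound 1 to compound 3 (1.29 log units; beyond the scatter), the first step in this set that can be traced to one place. It shows that this position is sensitive to the group it carries, since this single change, with the rest of compound 1 kept, moves the number by a large step, well beyond the scatter. No measurement at hand explains this step.

The cyclopropyl group leaves and the fluorine enters in the same change, so the compounds shown cannot separate the part each plays. As far as these compounds go, how a plain phenyl, or a phenyl bearing a methoxy group, would read on this carbon remains open.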